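Chloroacetamide series: further branching on the chain carbon

This account rests on a few compounds, and the source may have more. Where it says the series, first, only, none or still open, it means among the compounds named here.

Measured so far:
Compound 1 `C=CC(=O)Nc1cccc(-c2nc3ccccc3s2)c1` gives only a limit in an ADME assay on HepG2 cells (Homo sapiens) for inhibition, with a stated time of 72 h (a higher number here means that more compound is needed for the effect, a lower number that less compound is needed), > 25000 nM.
Compound 2 `O=C(CCl)Nc1cccc(-c2nc3ccccc3s2)c1` gives 16000 nM in this assay.
Compound 3 `CC(Cl)C(=O)Nc1cccc(-c2nc3ccccc3s2)c1` gives only a limit in this assay, > 25000 nM.

Compound 3 stands at the top of what the numbers show: its value is a limit, not a number, and it shares that position with compound 1 (the limit of > 25000 nM in this assay, at which 2 of the 3 values shown sit). For the measured compounds named here, the only numbered value in the set belongs to compound 2. The steps read as follows: an at least 1.5-fold lower number from compound 1 to compound 2 (0.19 log units; that floor lies within the scatter); an at least 1.5-fold higher number from compound 2 to compound 3 (0.19 log units; that floor lies within the scatter); a step that the two limits leave unreadable from compound 1 to compound 3.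

Compound 4 `CC(C)(CCl)C(=O)Nc1cccc(-c2nc3ccccc3s2)c1` carries the change (1-(chloromethyl)-1-methylethyl in place of 1-chloroethyl on a carbonyl carbon). Going by the values given here, the step that bears on it most directly is the one from compound 2 to compound 3, where a methyl entered on the same chain carbon and the number moved up to the limit; the step from compound 1 to compound 3 gives no readable size. A second methyl on that chain carbon is expected to leave compound 4 at or beyond the limit where compound 3 already sits, so the step from compound 3 to compound 4 is estimated as a step that the limit leaves unreadable from compound 3 to compound 4, with no reading beyond the scatter likely. Compound 4 is therefore estimated at 40000 nM, in the range 15000 nM to 120000 nM, most probably reported only as a limit.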

Compound 4, half-maximal effective concentration: > 25000 nM
Compound 4: no number, only a limit (the forecaster's own chance of this, stated with the estimate: 80%); the middle value does not contradict the limit.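

Replacing chloromethyl on a carbonyl carbon with 1-(chloromethyl)-1-methylethyl, the larger of the chlorine-bearing groups in the series, gives an at least 1.5-fold higher number from compound 2 to compound 4 (0.19 log units; that floor lies within the scatter). In this assay compound 4 gives > 25000 nM, which is a limit and not a number. The steps joining compound 4 to compound 1 and compound 3 cannot be read, and the heavier branching adds one more compound to the group at the limit, leaving compound 2 as the only one with a numbered value: the limit of > 25000 nM in this assay, at which 3 of the 4 values shown sit.

On these data alone, how far compound 1, compound 3 and compound 4 lie past that limit remains unknown, so no order among them can be stated, and whether any of them truly parts from compound 2 by more than the scatter also remains open. Also open, as far as these compounds go, is whether a bromomethyl group or a longer unbranched chain ending in chlorine on the same carbonyl carbon would give a numbered value in this assay.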